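Compound 3 after the limit of compound 2

This account rests on a few compounds, and the source may have more. Where it says the series, first, only, none or still open, it means among the compounds named here.

Measured so far in an unclassified assay for inhibition, read by fluorescence and spectrophotometry, with a stated time of 40 h; a higher number here means a weaker inhibitor, a lower number a stronger inhibitor
Compound 1 `O=C(/C=C/c1ccc(O)c(O)c1)OCCOc1no[n+]([O-])c1S(=O)(=O)c1ccccc1` gives 158000 nM
Compound 2 `O=C(/C=C/c1ccc(O)cc1)OCCOc1no[n+]([O-])c1S(=O)(=O)c1ccccc1` gives > 10000000 nM

Compound 2 stands at a limit and not at a number (the limit of > 10000000 nM in this assay, at which 1 of the 2 values shown sits). Compound 3 `O=C(OCCOc1no[n+]([O-])c1S(=O)(=O)c1ccccc1)c1ccc(O)c(O)c1` differs from compound 2 in one place (3,4-dihydroxyphenyl in place of 2-(4-hydroxyphenyl)ethenyl on a carbonyl carbon). Among the compounds with values here, one measured step bears on this change, and it is large (an at least 63-fold higher number from compound 1 to compound 2 (1.80 log units; beyond the scatter)). Compound 3 carries a 3,4-dihydroxyphenyl group, with the second hydroxy that compound 2 lacks. Taken in reverse, that step leads to the expectation of a large move to a lower number in this assay, towards compound 1 (158000 nM). Within the data shown here, no measured step covers the loss of the ethenyl part, so the expected range stays wide. The expected step is large and towards a stronger inhibitor (an at least 33-fold lower number from compound 2 to compound 3 (1.52 log units; beyond the scatter)). Compound 3 is expected at 300000 nM as the estimated middle, with an estimated range (60000 nM to 2500000 nM).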

Compound 3, half-maximal inhibitory concentration: 464000 nM
Estimate against measurement, compound 3: 1.5-fold (0.19 log units) below, within the range that was stated.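

Compound 2 stands at a limit of this assay and not at a number: the limit of > 10000000 nM in this assay, at which 1 of the 3 values shown sits. The replacement of 2-(4-hydroxyphenyl)ethenyl by 3,4-dihydroxyphenyl on the carbonyl carbon gives an at least 21-fold lower number from compound 2 to compound 3 (1.33 log units; beyond the scatter), so a measurable value does not depend on the ethenyl part. With both hydroxy groups kept, the loss of the ethenyl part costs far less than the loss of one hydroxy did, giving only a 2.9-fold higher number from compound 1 to compound 3 (0.47 log units; beyond the scatter), and the two compounds carrying both hydroxy groups give numbers while compound 2 does not.

The step from compound 2 to compound 3 changes the hydroxy count and the ethenyl part together, so it cannot separate their shares. From the compounds shown here alone, whether a methoxy group could stand in for either hydroxy, or a longer chain for the ethenyl part, remains open.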